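A few compounds are considered here, and "the series" means these few. Any claim that something is new, unique, unknown or untested is made for them only; others in the source may bear on it.

Compound 1 `O=C1O[C@@H](CO)CN1c1ccc(-n2cc(-c3ccccn3)cn2)c(F)c1`: in an ADME assay on HEK293-A cells (Homo sapiens) for cytotoxicity, read by MTT assay, with a stated time of 48 h (a higher number here means a weaker inhibitor, a lower number a stronger inhibitor), compound 1 gives > 400 ug/mL, which is a limit of the assay and not a number.
Compound 2 `O=C1O[C@@H](CN2CCC(c3ccc(F)cc3)CC2)CN1c1ccc(-n2cc(-c3ccccn3)cn2)c(F)c1`: in this assay compound 2 gives > 400 ug/mL, again a limit.
Compound 3 `O=C1CNC(=O)N1C[C@H]1CN(c2ccc(-n3cc(-c4ccccn4)cn3)c(F)c2)C(=O)O1`: in this assay compound 3 gives > 400 ug/mL, also a limit.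

Within the data shown here, compound 3 therefore stands exactly where every value so far stands, at the limit of > 400 ug/mL in this assay, at which 3 of the 3 values shown sit, and no ordering among the three compounds can be read. Among the measured compounds shown here, the only step between measured compounds, a step that the two limits leave unreadable from compound 1 to compound 3, is unreadable because the limit of > 400 ug/mL in this assay, at which 3 of the 3 values shown sit, hides both of its ends.

The new compound 4 `CN(C)S(=O)(=O)NC[C@H]1CN(c2ccc(-n3cc(-c4ccccn4)cn3)c(F)c2)C(=O)O1` differs from compound 3 by (dimethylsulfamoyl)amino in place of 2,5-dioxoimidazolidin-1-yl on a saturated chain carbon bound to a saturated ring carbon. For the measured compounds named here, no measured step tells how far a change of this kind can move the read-out, since a step that the two limits leave unreadable from compound 1 to compound 3 has no size. The step of a number no higher from compound 3 to compound 4 (the limit leaves the size open) is thus expected to show no change beyond the scatter. The estimate for compound 4 in this assay is 400 ug/mL, between 150 ug/mL and 1000 ug/mL, most likely reported once more only as a limit.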

Compound 4, half-maximal inhibitory concentration: 249 ug/mL
The estimate for compound 4 lay 1.6-fold (0.21 log units) above the measured number, within the range that was stated.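

Among these compounds, at the place on a saturated chain carbon bound to a saturated ring carbon, compound 4 is the first compound here to give a real number in this assay, so a group at this place can bring the read-out into the range the assay can count. Replacing the 2,5-dioxoimidazolidin-1-yl group gives an at least 1.6-fold lower number from compound 3 to compound 4 (0.20 log units; that floor lies within the scatter), and replacing the hydroxy gives an at least 1.6-fold lower number from compound 1 to compound 4 (0.20 log units; that floor lies within the scatter). On these data alone, their true sizes stay open, and the step from the hydroxy to the 2,5-dioxoimidazolidin-1-yl group cannot be read, because the other values are a limit and not numbers: the limit of > 400 ug/mL in this assay, at which 3 of the 4 values shown sit.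

The compounds shown leave open whether the sulfur or the opened ring goes with the countable value. An amine or a carboxylic acid on the same chain carbon could show how widely this place tolerates change.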